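The source may report more compounds than this note shows. Statements on the series, on what has been measured and on what is new or still open speak of the compounds shown alone.

Measured so far in a functional assay on H184B5F5/M10 cells (Homo sapiens) for antiproliferative activity, read by XTT assay, with a stated time of 72 h; a higher number here means a weaker inhibitor, a lower number a stronger inhibitor:
compound 1, `COc1ccc(-c2cc3ccccc3nc2/C=C/C(=O)c2ccc(O)cc2)cc1`, 5690 nM
compound 2, `COc1ccc(-c2cc3ccccc3nc2/C=C/C(=O)c2c(OC)cccc2OC)cc1`, 4470 nM

Both compounds share the same core and differ only in the group attached to the carbonyl carbon. Compound 1 cannot be told apart from compound 2 on these numbers: the step of a 1.3-fold lower number from compound 1 to compound 2 (0.10 log units; within the scatter) lies within the scatter of this assay, so the two results are to be read as the same.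

Compound 3, `COc1ccc(-c2cc3ccccc3nc2/C=C/C(=O)c2ccc[nH]2)cc1`, is not yet measured. It differs from compound 1 at that same carbonyl carbon: 1H-pyrrol-2-yl in place of 4-hydroxyphenyl on a carbonyl carbon.

For the measured compounds named here, the only measured step that bears on this change is the one from compound 1 to compound 2, which also swapped the group on the carbonyl carbon and gave a 1.3-fold lower number from compound 1 to compound 2 (0.10 log units; within the scatter), a change too small to count. On that single piece of evidence the group on the carbonyl carbon seems to matter little, and the step of a 1.1-fold lower number from compound 1 to compound 3 (0.04 log units; within the scatter) is expected to stay within the scatter as well. Compound 3 is therefore estimated at 5200 nM in this assay, with a range from 1700 nM to 16000 nM.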

Compound 3, half-maximal inhibitory concentration: > 10000 nM
Compound 3 ended at the assay's limit; the forecaster's own chance of this, stated with the estimate: 5%; middle value at least 1.9-fold (0.28 log units) away from the limit.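

The reading for compound 3 in this assay is a limit of the assay, not a number: the limit of > 10000 nM in this assay, at which 1 of the 3 values shown sits. Even so, the swap of group on the carbonyl carbon now produces a real difference (an at least 2.2-fold higher number from compound 2 to compound 3 (0.34 log units; beyond the scatter)), so this position is not indifferent to what sits on it, something the earlier pair of compound 1 and compound 2 could not show. On these data alone, measured against the 4-hydroxyphenyl group, the result is less firm (an at least 1.7-fold higher number from compound 1 to compound 3 (0.24 log units; that floor lies within the scatter)): the 1H-pyrrol-2-yl group may do worse than 4-hydroxyphenyl, but the floor of that step does not settle it, and the true size of the gap stays unknown.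

The compounds shown do not reveal which feature of the 1H-pyrrol-2-yl group goes with the weaker reading, since its five-membered ring and its nitrogen arrive together, while the count of hydrogen-bond donors matches that of 4-hydroxyphenyl. They also leave open how a plain phenyl ring, a pyridine ring, an amine or a short alkyl chain on the carbonyl carbon would behave in this assay, including whether any ring is needed there at all.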